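A few compounds are considered here, and "the series" means these few. Any claim that something is new, unique, unknown or untested is made for them only; others in the source may bear on it.

For the measured compounds named here, in a functional assay on NCI-H460 cells (Homo sapiens) for cytotoxicity, read by MTT assay, with a stated time of 72 h (a higher number here means a weaker inhibitor, a lower number a stronger inhibitor), compound 1 `CN(C)Cc1ccc2nc(NC(=O)N/N=C/c3c[nH]c4ccccc34)sc2c1` gives 2550 nM as its reading, while compound 2 `CN(C)Cc1ccc2nc(NC(=O)N/N=C/c3cn(Cc4cccc(Cl)c4)c4ccccc34)sc2c1` gives 420 nM as the lower of the two numbers so far. Compound 3 `CN(C)Cc1ccc2nc(NC(=O)N/N=C/c3cn(Cc4ccc(Cl)c(Cl)c4)c4ccccc34)sc2c1` differs from compound 2 in one place chloro in place of hydrogen on an aromatic carbon with chloro in place of hydrogen on an aromatic carbon, so that 3-chlorobenzyl becomes 3,4-dichlorobenzyl. Going by the values given here, only one measured step bears on this change. The step of a 6.1-fold lower number from compound 1 to compound 2 (0.78 log units; beyond the scatter) came with 3-chlorobenzyl in place of hydrogen on an aromatic nitrogen. That step added a whole group, whereas the new change adds a single atom to that group. A much smaller step in the same downward direction is therefore expected in this assay and it may stay within the scatter. The estimated move is a 1.4-fold lower number from compound 2 to compound 3 (0.15 log units; within the scatter) as a modest one at best. The estimate for compound 3 is 300 nM with an expected range from 120 nM to 700 nM.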

Compound 3, half-maximal inhibitory concentration: 1360 nM
Estimate against measurement, compound 3: 4.5-fold (0.66 log units) below; measured number outside the range, above it.
By their numbers in this assay, from the lowest: compound 2; then compounds 3 and 1 (each within the scatter of the next).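

In this assay, the chloro that enters para to a large group and ortho to the existing chloro gives a 3.2-fold higher number from compound 2 to compound 3 (0.51 log units; beyond the scatter), so one added atom at this position runs against the direction of the step that first placed 3-chlorobenzyl on the nitrogen. With 3,4-dichlorobenzyl in place of the hydrogen on that nitrogen, the result is a 1.9-fold lower number from compound 1 to compound 3 (0.27 log units; within the scatter), so the clear advantage seen with 3-chlorobenzyl does not carry over to this group. Nothing available here accounts for the effect of the second chloro.

On these data alone, it remains open whether this rise in the number is specific to chloro or would also appear with a methyl or methoxy group at the same position. A 4-chlorobenzyl group, carrying only the new chloro, could read close to either compound 2 or compound 3.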